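Nitroaryl Ester Compared with Its Fluorinated Relatives

The source may report more compounds than this note shows. Statements on the series, on what has been measured and on what is new or still open speak of the compounds shown alone.

Compound 1 `C=C(C(=O)c1ccc(OC)cc1)C(OC(C)=O)c1ccccc1F` gives 9500 nM in a functional assay on NB-4 cells (Homo sapiens) for inhibition, read by XTT assay, with a stated time of 48 h; a lower number here means a stronger inhibitor, a higher number a weaker inhibitor. Compound 2 `C=C(C(=O)c1ccc(OC)cc1)C(OC(C)=O)c1c(F)c(F)c(F)c(F)c1F` gives 12600 nM in this assay, and compound 3 `C=C(C(=O)c1ccc(OC)cc1)C(OC(=O)c1ccccc1)c1ccccc1F` gives 14300 nM. Compound 3 has the highest number of the three, yet its gaps to compound 2 and to compound 1 both lie within the scatter, so the three cannot be ranked. The step of a 1.5-fold higher number from compound 1 to compound 3 (0.18 log units; within the scatter) shows that exchanging the ester group moved the number only within the scatter. Compound 4 `C=C(C(=O)c1ccc(OC)cc1)C(OC(=O)c1ccccc1)c1ccc([N+](=O)[O-])cc1` differs from compound 3 by 4-nitrophenyl in place of 2-fluorophenyl on a saturated chain carbon bound to a double-bonded chain carbon and an oxygen next to a carbonyl group. Within the data shown here, no measured step covers this exchange; compound 1 and compound 2, which differ in their aryl group, give numbers within the scatter of each other, so little movement is expected. The step from compound 3 to compound 4 is estimated as a 1.1-fold lower number from compound 3 to compound 4 (0.04 log units; within the scatter). Compound 4 is expected to give 13000 nM in this assay, within a range of 5000 nM to 35000 nM.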

Compound 4, half-maximal inhibitory concentration: 13200 nM
Compound 4: middle estimate off by 1.0-fold (0.01 log units), on the low side; the range from low to high includes it.
By their numbers in this assay, from the lowest: compounds 1, 2, 4 and 3 (each within the scatter of the next).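

In this assay the step of a 1.1-fold lower number from compound 3 to compound 4 (0.03 log units; within the scatter) stays within the scatter, so 4-nitrophenyl and 2-fluorophenyl cannot be told apart at this position. The earlier compounds shown here carried only fluorinated aryl groups here, whereas compound 4 brings in an aryl group with no fluorine, and the number still does not shift beyond the scatter. No supporting measurement is available to explain this result. On these data alone, whether an amine or a carboxylic acid in this place would move the number remains open, as does the outcome of a longer chain on the ester carbonyl.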